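This account rests on a few compounds, and the source may have more. Where it says the series, first, only, none or still open, it means among the compounds named here.

Compound 1 `COc1ccc(S(=O)(=O)N2CCN(c3nc(N)c4cc(OC)c(OC)cc4n3)CC2)cc1`: 39000 nM
Compound 2 `COc1cc2nc(N3CCN(S(=O)(=O)c4ccc(OC(F)(F)F)cc4)CC3)nc(N)c2cc1OC`: 25000 nM
Compound 3 `COc1cc2nc(N3CCN(S(=O)(=O)c4ccc(S(C)(=O)=O)cc4)CC3)nc(N)c2cc1OC`: 17000 nM

The three measured compounds share one core and differ only in the group on the aromatic carbon of the sulfonyl-bearing ring. In a functional assay on PC-3 cells (Homo sapiens) for inhibition (on this read-out lower numbers stand for stronger inhibition and higher numbers for weaker inhibition), compound 3 gives 17000 nM. The step of a 2.3-fold lower number from compound 1 to compound 3 (0.36 log units; beyond the scatter) lies beyond the scatter, whereas a 1.5-fold lower number from compound 2 to compound 3 (0.17 log units; within the scatter) and a 1.6-fold lower number from compound 1 to compound 2 (0.19 log units; within the scatter) do not, so compound 3 is set apart only from compound 1.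

Compound 4 `COc1cc2nc(N3CCN(S(=O)(=O)c4ccc(-c5ccc(C(C)(C)C)cc5)cc4)CC3)nc(N)c2cc1OC` differs from compound 3 by 4-(tert-butyl)phenyl in place of methylsulfonyl on an aromatic carbon. No measured step carries a change of this kind; the three steps shown all exchange one group for another at the same aromatic carbon, and the largest of them, a 2.3-fold lower number from compound 1 to compound 3 (0.36 log units; beyond the scatter), is modest. The spread of the three values is narrow, and nothing in them points to a direction for this change. Compound 4 is therefore expected to give about 15000 nM in this assay, within a range of 4000 nM to 60000 nM. That estimate means a step of a 1.1-fold lower number from compound 3 to compound 4 (0.05 log units; within the scatter), which is expected to stay within the scatter, with wide uncertainty on either side.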

Compound 4, half-maximal inhibitory concentration: 10000 nM
Compound 4: the middle estimate sits 1.5-fold (0.18 log units) above what was measured, within the range that was stated.
By their numbers in this assay, from the lowest: compounds 4, 3, 2 and 1 (each within the scatter of the next, the first and the last beyond it).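

In this assay, this aromatic carbon accepts 4-(tert-butyl)phenyl, a group with a six-membered aromatic ring of its own and no hydrogen-bond acceptors, with no loss of inhibition: a 1.7-fold lower number from compound 3 to compound 4 (0.23 log units; within the scatter) stays within the scatter, so the exchange for methylsulfonyl cannot be read as a gain. Against the other two groups the change does register, with a 2.5-fold lower number from compound 2 to compound 4 (0.40 log units; beyond the scatter) and a 3.9-fold lower number from compound 1 to compound 4 (0.59 log units; beyond the scatter), the latter the largest step among these compounds, though still modest. No measurement shown explains why this large group is accepted here.

The compounds shown leave open how an amine or a carboxylic acid would read at this aromatic carbon. They also leave open whether the tert-butyl end matters, which plain phenyl in its place would test.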